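This account rests on a few compounds, and the source may have more. Where it says the series, first, only, none or still open, it means among the compounds named here.

Measured compounds:
- compound 1 `COc1cccc(Cc2ccnn(CC(=O)Nc3ccc(Br)cc3)c2=O)c1`: in a functional assay on HL-60 cells (Homo sapiens), read by calcium flux (a higher number here means that more compound is needed for the effect, a lower number that less compound is needed), compound 1 reaches only the assay limit, > 50000 nM.
- compound 2 `COc1cccc(Cc2cc(-c3cccs3)nn(CC(=O)Nc3ccc(F)cc3)c2=O)c1`: in this assay compound 2 likewise stops at the assay limit, > 50000 nM.
- compound 3 `COc1ccc(Cc2cc(-c3ccc(OC)cc3)nn(CC(=O)Nc3ccc(Br)cc3)c2=O)cc1`: in this assay compound 3 also stops at the assay limit, > 50000 nM.

For compound 2 only a limit is known, not a number, and the two further values shown in this assay are limits as well; all three values sit at the limit of > 50000 nM in this assay, at which 3 of the 3 values shown sit. Within the data shown here, no two of the measured compounds differ in a single place, so no measured step in this assay can be counted, and none of the three gives a readable number from which a direction could be taken.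

Compound 4 `COc1cccc(Cc2cc(-c3ccc(C)cc3)nn(CC(=O)Nc3ccc(F)cc3)c2=O)c1` differs from compound 2 by 4-methylphenyl in place of thiophen-2-yl on an aromatic carbon. With every value in the series resting at the limit, nothing points to a change beyond the scatter in this assay. The step expected from compound 2 to compound 4, a number no higher from compound 2 to compound 4 (the limit leaves the size open), is therefore none beyond the scatter. Compound 4 is expected to give 50000 nM in this assay, with a range from 20000 nM to 120000 nM, and most likely to be reported only as a limit.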

Compound 4, half-maximal effective concentration: > 50000 nM
Compound 4 ended at the assay's limit (the forecaster's own chance of this, stated with the estimate: 85%); the middle value sits exactly at the limit.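

No step can be read from compound 2 to compound 4, with 4-methylphenyl in place of thiophen-2-yl, since both values are limits and not numbers: the limit of > 50000 nM in this assay, at which 4 of the 4 values shown sit.

The compounds shown leave open whether any change to the shared core gives a readable number in this assay.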